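Dichlorophenyl Urea Variant Tested Against Ret V804L

The source may hold more compounds than are shown below. What is called first, only, known or untested is meant among the compounds shown, and "the series" means these compounds.

In an assay on isolated protein for inhibition of proto-oncogene tyrosine-protein kinase receptor Ret variant V804L (Homo sapiens), read by 33P incorporation, with stated times of 15 min and 40 min (on this read-out lower numbers stand for stronger inhibition and higher numbers for weaker inhibition), compound 1 `O=C(Nc1ccc(Nc2ncnc3c2OCCN3)cc1)Nc1ccc(C(F)(F)F)cc1` gives 2470 nM. Compound 2 `COc1cccc(NC(=O)Nc2ccc(Nc3ncnc4c3OCCN4)cc2)c1` reaches only the assay limit, > 10000 nM, in this assay. Within the data shown here, compound 3 `Cc1ccc(F)c(NC(=O)Nc2ccc(Nc3ncnc4c3OCCN4)cc2)c1` gives 7000 nM, the higher of the two numbers known, with a 2.8-fold higher number from compound 1 to compound 3 (0.45 log units; beyond the scatter) separating it from its nearest neighbour. Compound 4 `O=C(Nc1ccc(Nc2ncnc3c2OCCN3)cc1)Nc1cc(Cl)cc(Cl)c1` differs from compound 3 by 3,5-dichlorophenyl in place of 2-fluoro-5-methylphenyl on an amide-type nitrogen. Among the measured compounds shown here, the steps that bear on this change are a 2.8-fold higher number from compound 1 to compound 3 (0.45 log units; beyond the scatter) and an at least 1.4-fold lower number from compound 2 to compound 3 (0.15 log units; that floor lies within the scatter), both swaps of the aryl group on the same amide-type nitrogen, and both modest; a 3,5-dichlorophenyl group has not been measured here. Compound 4 is therefore expected to give 4000 nM, between 1500 nM and 10000 nM, a step of a 1.8-fold lower number from compound 3 to compound 4 (0.24 log units; within the scatter) whose direction remains uncertain.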

Compound 4, half-maximal inhibitory concentration: 4480 nM
Beside the measured number, compound 4's estimate is 1.1-fold (0.05 log units) below it; the measured number falls inside the stated range.
By their numbers in this assay, from the lowest: compounds 1, 4 and 3 (each within the scatter of the next, the first and the last beyond it). At a limit, above all of these: compound 2.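

On this amide-type nitrogen, 3,5-dichlorophenyl cannot be told apart from either of the two aryl groups it is compared with here, with a 1.6-fold lower number from compound 3 to compound 4 (0.19 log units; within the scatter) and a 1.8-fold higher number from compound 1 to compound 4 (0.26 log units; within the scatter). It does separate from 3-methoxyphenyl, with an at least 2.2-fold lower number from compound 2 to compound 4 (0.34 log units; beyond the scatter). The value of compound 2 in that step is a limit of the assay: the limit of > 10000 nM in this assay, at which 1 of the 4 values shown sits.

The compounds shown leave open whether a single chlorine would read the same as two. They also leave open whether a nitrile or an amine on the aryl ring, or cyclohexyl in its place, would move the number beyond this band.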